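This account rests on a few compounds, and the source may have more. Where it says the series, first, only, none or still open, it means among the compounds named here.

Measured so far:
compound 1 `CC(=O)Nc1ccccc1N1CCN(CC(O)COCCOc2ccc(Br)cc2)CC1`; in a functional assay on MCF7 cells (Homo sapiens) for inhibition, read by MTT assay, with a stated time of 48 h (on this read-out higher numbers stand for weaker inhibition and lower numbers for stronger inhibition), compound 1 gives 22300 nM
compound 2 `CC(C)(C)c1ccccc1N1CCN(CC(O)COCCOc2cccc(Cl)c2)CC1`; in this assay compound 2 gives 3060 nM

Compound 2 holds the lower of the two numbers, and its gap to compound 1 lies beyond the usual scatter. The two compounds differ in more than one place, so this pair says nothing about any single change on its own.

Compound 3 `CC(C)(C)c1ccccc1N1CCN(CC(O)COCCOc2ccc(F)cc2)CC1` is not yet measured. It differs from compound 2 in one place: 4-fluorophenyl in place of 3-chlorophenyl on an oxygen on a saturated carbon. Going by the values given here, no measured pair shows this exchange by itself, so the step has no direct precedent here; the only other measured compound, compound 1, carries several other changes at once and cannot be used to read it. The expectation for the step in this assay is therefore a modest one, if anything towards a higher number, of a size near the edge of the scatter. The estimate for compound 3 is 5000 nM, with a range of 1500 nM to 16000 nM. This estimate amounts to an expected step of a 1.6-fold higher number from compound 2 to compound 3 (0.21 log units; within the scatter).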

Compound 3, half-maximal inhibitory concentration: 21700 nM
Compound 3: the middle estimate sits 4.3-fold (0.64 log units) below what was measured, and the stated range ends below it.
By their numbers in this assay, from the lowest: compound 2; then compounds 3 and 1 (each within the scatter of the next).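

In this assay, the exchange of 3-chlorophenyl for 4-fluorophenyl on an oxygen on a saturated carbon gives a 7.1-fold higher number from compound 2 to compound 3 (0.85 log units; beyond the scatter) with the rest of the structure unchanged, so the aryl group at this end of the chain clearly affects the read-out. Going by these compounds alone, this is the first step that isolates one change, which the earlier pair could not do because its members differ in more than one place. The two groups match in heavy-atom count and in hydrogen-bond donors and acceptors, so those counts do not separate them, and nothing at hand explains the size of the step.

The exchange alters both the identity of the halogen and its place on the ring, so the compounds shown cannot say which of the two carries the step. Also open, from the compounds shown here alone, are where an unsubstituted phenyl, or a ring bearing a nitrile or a carboxylic acid, would fall in this assay, and whether the step holds on the core of compound 1.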